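Adding a nitro group to the piperazine phenyl in compound 1

The compounds below may be only part of what the source reports. "The series", "measured", "known", "first", "only" and "open" are said of these compounds alone.

Compound 1 `CCCCCCCCCCn1cc(/C=C/C(=O)c2ccc(NC(=O)CN3CCN(c4ccccc4)CC3)cc2)nn1` is tested in a functional assay on MCF7 cells (Homo sapiens) for inhibition, read by MTT assay; a lower number here means a stronger inhibitor, a higher number a weaker inhibitor. In this assay compound 1 gives > 100000 nM, which is a limit of the assay and not a measured number (the limit of > 100000 nM in this assay, at which 1 of the 2 values shown sits). Compound 2 `O=C(CN1CCN(c2ccccc2)CC1)Nc1ccc(C(=O)/C=C/c2cn(Cc3ccc(Br)cc3)nn2)cc1` differs from compound 1 at the other end of the molecule; in this assay compound 2 gives 49200 nM, and the change is an at least 2.0-fold lower number from compound 1 to compound 2 (0.30 log units; that floor lies within the scatter). Compound 3 `CCCCCCCCCCn1cc(/C=C/C(=O)c2ccc(NC(=O)CN3CCN(c4ccc([N+](=O)[O-])cc4)CC3)cc2)nn1` carries instead a change on the phenyl attached to the piperazine: nitro in place of hydrogen on an aromatic carbon. Going by the values given here, no measured step touches this part of the molecule, so the step from compound 1 to compound 2 gives no guide to how compound 3 will behave. With compound 1 known only as a limit, compound 3 is expected to stay near that limit, meaning an estimated step of a number no higher from compound 1 to compound 3 (the limit leaves the size open). The estimated value for compound 3 is 100000 nM, with a range from 30000 nM to 300000 nM.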

Compound 3, half-maximal inhibitory concentration: 44400 nM
Compound 3: the middle estimate sits 2.3-fold (0.35 log units) above what was measured; low and high end bracket the measured number.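

Nitro in place of hydrogen on the phenyl attached to the piperazine gives an at least 2.2-fold lower number from compound 1 to compound 3 (0.35 log units; beyond the scatter) in this assay. The earlier step changed only the group on the aromatic nitrogen, so this result adds a second place in the molecule where a single change moves the number, here with the nonyl chain left as it is. The true size of the step stays open, since compound 1 is known only as a limit of the assay: the limit of > 100000 nM in this assay, at which 1 of the 3 values shown sits.

Nitro is the only group shown on this phenyl, so it remains open whether an amine, a methoxy group or a chlorine atom in the same place would move the number as well. Going by these compounds, it is also open whether nitro would give a similar step when added to compound 2.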